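From Ethyl to Cyclopropyl on the Carbonyl Carbon

The compounds below may be only part of what the source reports. "The series", "measured", "known", "first", "only" and "open" are said of these compounds alone.

Within the data shown here, in a functional assay on SK-BR-3 cells (Homo sapiens) for antiproliferative activity (on this read-out higher numbers stand for weaker inhibition and lower numbers for stronger inhibition), compound 2 `CCC(=O)Nc1cc2ccc(O[C@@H]3OC(C)(C)[C@H](OC)[C@@H](O)[C@H]3O)c(C)c2oc1=O` gives 643000 nM as the higher of the two numbers so far, while compound 1 `CO[C@@H]1[C@@H](O)[C@@H](O)[C@H](Oc2ccc3cc(NC(=O)C4CCCC4)c(=O)oc3c2C)OC1(C)C` stands at 67000 nM as the lower. Compound 3 `CO[C@@H]1[C@@H](O)[C@@H](O)[C@H](Oc2ccc3cc(NC(=O)C4CC4)c(=O)oc3c2C)OC1(C)C` has cyclopropyl in place of ethyl on a carbonyl carbon. Among the measured compounds shown here, one measured step bears on this: ethyl in place of cyclopentyl gave a 9.6-fold higher number from compound 1 to compound 2 (0.98 log units; beyond the scatter) and counts as modest. With a ring back on the carbonyl carbon, part of that step is expected to reverse in this assay as a lower number, and the estimate is a 2.6-fold lower number from compound 2 to compound 3 (0.41 log units; beyond the scatter) for this change. Compound 3 is expected near 250000 nM (70000 nM to 800000 nM).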

Compound 3, half-maximal inhibitory concentration: 517000 nM
For compound 3 the middle estimate is 2.1-fold (0.32 log units) below the measured one; measured number inside the range.
By their numbers in this assay, from the lowest: compound 1; then compounds 3 and 2 (each within the scatter of the next).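

Cyclopropyl on the carbonyl carbon gives a 1.2-fold lower number from compound 2 to compound 3 (0.09 log units; within the scatter) in this assay and so cannot be told apart from ethyl: a ring alone does not match cyclopentyl. Compared directly with cyclopentyl, it gives a 7.7-fold higher number from compound 1 to compound 3 (0.89 log units; beyond the scatter) and leaves compound 1 as the only one of the three that stands apart. Nothing available here explains this difference between the two rings. Cyclobutyl and cyclohexyl would show how the number follows ring size between and beyond these two rings. A longer open chain, such as pentyl, would show whether a ring is needed at all.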